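The source may hold more compounds than are shown below. What is called first, only, known or untested is meant among the compounds shown, and "the series" means these compounds.

In an ADME assay on NIH3T3 cells (Mus musculus) for cytotoxicity, read by MTT assay, with a stated time of 24 h (on this read-out higher numbers stand for weaker inhibition and lower numbers for stronger inhibition), compound 3 `O=C(CSc1nnnn1-c1ccccc1)N/N=c1/scc(-c2ccccc2)n1-c1ccccc1` gives 417 ug/mL, the highest of the two numbers shown. Its nearest neighbour, compound 2 `Cn1nnnc1SCC(=O)N/N=c1/scc(-c2ccccc2)n1-c1ccccc1`, gives 173 ug/mL in this assay, so that a 2.4-fold higher number from compound 2 to compound 3 (0.38 log units; beyond the scatter). Compound 1 `Cc1ccc(-c2cs/c(=N/NC(=O)CSc3nnnn3-c3ccccc3)n2-c2ccccc2)cc1` reaches only a limit of this assay, > 500 ug/mL. From there, an at least 1.1-fold lower number from compound 1 to compound 3 (0.07 log units; that floor lies within the scatter).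

Compound 4 `O=C(CSc1nnnn1-c1ccccc1)N/N=c1/scc(-c2ccc(Cl)cc2)n1-c1ccccc1` differs from compound 3 by a single change, (chloro in place of hydrogen on an aromatic carbon). Among the measured compounds shown here, no measured step swaps a hydrogen for a chloro; the closest comparison is the methyl-for-hydrogen step on an aromatic carbon, which stays within the scatter, and the only step beyond the scatter concerns a different position. The expectation is therefore a step of no clear size, a 1.1-fold lower number from compound 3 to compound 4 (0.04 log units; within the scatter). Compound 4 is expected to give 380 ug/mL, between 150 ug/mL and 600 ug/mL, in this assay.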

Compound 4, half-maximal inhibitory concentration: 313 ug/mL
Beside the measured number, compound 4's estimate is 1.2-fold (0.08 log units) above it, and the stated range covers the measured number.
By their numbers in this assay, from the lowest: compounds 2, 4 and 3 (each within the scatter of the next, the first and the last beyond it). At a limit, above all of these: compound 1.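

In this assay chloro in place of hydrogen on this aromatic carbon gives a 1.3-fold lower number from compound 3 to compound 4 (0.12 log units; within the scatter) and so has no clear effect at this place. Compound 1, with methyl at the same place, gives > 500 ug/mL which is a limit of the assay. Chloro in place of methyl gives an at least 1.5-fold lower number from compound 1 to compound 4 (0.20 log units; that floor lies within the scatter) and the full size of that step stays unknown because compound 1 sits at that limit: the limit of > 500 ug/mL in this assay, at which 1 of the 4 values shown sits.

As far as these compounds go, whether an amine or a carboxylic acid at this place would move the number beyond the scatter remains open.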